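The source may report more compounds than this note shows. Statements on the series, on what has been measured and on what is new or still open speak of the compounds shown alone.

Compound 1 `C=Cc1cn([C@H]2C[C@H](O)[C@@H](CO)O2)c(=O)[nH]c1=O` is the only one of the three measured compounds to return a number in an ADME assay on L1210/0 cells (Mus musculus) for cytotoxicity, with a stated time of 48 h; a lower number here means a stronger inhibitor, a higher number a weaker inhibitor: compound 1 gives 14200 nM. Compound 2 `OC[C@H]1CCC[C@@H]1n1cnc2c(Cl)ncnc21` reaches only the assay limit of > 200000 nM in this assay. Compound 3 `C[C@@]1(CO)O[C@H](c2cc(F)c(N)cc2F)C[C@@H]1O` likewise sits at the limit of > 200000 nM. For the measured compounds named here, the series is thus dominated by the limit of > 200000 nM in this assay, at which 2 of the 3 values shown sit, leaving compound 1 as the single resolved value. Compound 4 `CCCC/C=C\c1cn([C@H]2C[C@H](O)[C@@H](CO)O2)c(=O)[nH]c1=O` is not yet measured; it differs from compound 1 by hex-1-en-1-yl in place of vinyl on an aromatic carbon. Going by the values given here, no measured pair differs in a single place, so no comparable step is available. The longer chain is expected to shift potency little, or toward weaker inhibition; the expected step is a 2.1-fold higher number from compound 1 to compound 4 (0.32 log units; beyond the scatter). Compound 4 is estimated near 30000 nM, within 8000 nM to 150000 nM.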

Compound 4, half-maximal inhibitory concentration: > 200000 nM
Compound 4 ended at the assay's limit; the forecaster's own chance of this, stated with the estimate: 20%; at least 6.6-fold (0.82 log units) between middle value and limit.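

For the compounds shown here, this is the first readable step: at this aromatic carbon, hex-1-en-1-yl in place of vinyl gives an at least 14-fold higher number from compound 1 to compound 4 (1.14 log units; beyond the scatter) in this assay. Compound 4 carries a limit and not a number, so the step is only a lower bound. The position does not accept every alkenyl chain, and a resolved value remains the exception: the limit of > 200000 nM in this assay, at which 3 of the 4 values shown sit.

On these data alone, whether a shorter chain such as but-1-en-1-yl, or a saturated ethyl group, keeps a resolved value at this carbon stays open. Also open, as far as these compounds go, is whether an amine or a hydroxyl at the end of the longer chain would return a number.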